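The source may hold more compounds than are shown below. What is called first, only, known or untested is meant among the compounds shown, and "the series" means these compounds.

In an assay on CHO cells for displacement of a labelled ligand from adenosine receptor A3 (Homo sapiens), read by scintillation counting, with a stated time of 3 h (a lower number here means a stronger inhibitor, a higher number a weaker inhibitor), compound 1 `Cc1nc(NC(=O)c2ccccc2)c2nc(-c3ccccc3)sc2n1` gives 691 nM. Compound 2 `Cc1nc(NC(=O)c2ccc(Cl)cc2)c2nc(-c3ccccc3)sc2n1`, which carries a chloro in place of hydrogen on an aromatic carbon, gives > 30000 nM in this assay, and this is a limit rather than a number. Compound 2 thus stands at the limit of > 30000 nM in this assay, at which 1 of the 2 values shown sits. Among the compounds with values here, the step of an at least 43-fold higher number from compound 1 to compound 2 (1.63 log units; beyond the scatter) is the only measured step on record here, and it runs toward weaker binding.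

Compound 3 `COc1ccc(C(=O)Nc2nc(C)nc3sc(-c4ccccc4)nc23)cc1` follows from compound 2 by methoxy in place of chloro on an aromatic carbon. Within the data shown here, no measured step speaks directly to the exchange of chloro for methoxy at this position; the one step that bears on it shows only that a substituent at this carbon, the chloro of compound 2, moved the number far beyond the scatter and out of the measurable range. With a methoxy in the same place, the account expects compound 3 to remain weak, though without the chloro the number might fall back into range. Compound 3 is therefore estimated at 20000 nM, within a range from 3000 nM to 100000 nM. The expected step is an at least 1.5-fold lower number from compound 2 to compound 3 (0.17 log units; that floor lies within the scatter).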

Compound 3, inhibition constant: 91 nM
Compound 3: the middle estimate sits 220-fold (2.34 log units) above what was measured; measured number below the stated range.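

The result shows that this carbon, on a six-membered aromatic ring of carbon only and para to a large group, does not simply reject a substituent: going from 4-chlorophenyl to 4-methoxyphenyl gives an at least 320-fold lower number from compound 2 to compound 3 (2.51 log units; beyond the scatter) in this assay and so the identity of the group decides the outcome. Set against the unsubstituted phenyl of compound 1, the methoxy moves the number in the opposite direction to the chloro, with a 7.6-fold lower number from compound 1 to compound 3 (0.88 log units; beyond the scatter) and thus a modest improvement where the chloro brought a large loss. Compound 2 stands at a limit and not at a number: (the limit of > 30000 nM in this assay, at which 1 of the 3 values shown sits).

Among the compounds shown, only hydrogen, chloro and methoxy occupy this carbon, so it remains open whether the improvement belongs to methoxy alone or would also appear with a hydroxy, an ethoxy or an amine. On these data alone, it is equally open how a longer chain would fare at this carbon, and whether a methoxy at another carbon of the same ring would give a similar number.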